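Removing the Cyclohexyl Group: Expected Loss of Potency

A few compounds are considered here, and "the series" means these few. Any claim that something is new, unique, unknown or untested is made for them only; others in the source may bear on it.

Measured compounds:
Compound 1 `CCn1c(-c2ccccc2)nc2c(NC3CCCCC3)ncnc21` gives 9020 nM in a functional assay on CHO cells for antagonist activity at adenosine receptor A2b (Homo sapiens), read by 33P incorporation, with a stated time of 20 min; on this read-out lower numbers stand for stronger inhibition and higher numbers for weaker inhibition.
Compound 2 `Cn1c(-c2ccccc2)nc2c(NC3CCCCC3)ncnc21` gives > 30000 nM in this assay; that figure is a limit, not a number.
Compound 3 `CCCn1c(-c2ccccc2)nc2c(NC3CCCCC3)ncnc21` gives 5310 nM in this assay.

Among the two numbers actually given, compound 1 carries the higher one, but the step of a 1.7-fold lower number from compound 1 to compound 3 (0.23 log units; within the scatter) lies within the usual scatter, so the two cannot be ordered. The other steps concern the same chain on the aromatic nitrogen: an at least 3.3-fold higher number from compound 1 to compound 2 (0.52 log units; beyond the scatter) and an at least 5.6-fold lower number from compound 2 to compound 3 (0.75 log units; beyond the scatter) show that a longer chain there goes with a lower number.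

Compound 4 `CCn1c(-c2ccccc2)nc2c(N)ncnc21` differs from compound 1 at another site: hydrogen in place of cyclohexyl on a nitrogen on an aromatic ring, so the cyclohexylamino becomes a plain amino group. Among the measured compounds shown here, none of the measured steps touches this part of the shared core, so there is no direct guide to the size of the step. The expectation rests only on the observation that compound 1 already sits at a weak level of inhibition, so the step from compound 1 to compound 4 is estimated as a 2.2-fold higher number from compound 1 to compound 4 (0.35 log units; beyond the scatter), toward weaker inhibition. Compound 4 is therefore expected to give about 20000 nM, somewhere between 5000 nM and 60000 nM, with a real chance that this assay reports only a limit.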

Compound 4, inhibition constant: 3020 nM
For compound 4 the middle estimate is 6.6-fold (0.82 log units) above the measured one; the measured number lies below the stated range.
By their numbers in this assay, from the lowest: compounds 4, 3 and 1 (each within the scatter of the next, the first and the last beyond it). At a limit, above all of these: compound 2.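

The cyclohexyl group on this nitrogen is not needed for the activity seen in this assay: replacing it with hydrogen gives a 3.0-fold lower number from compound 1 to compound 4 (0.48 log units; beyond the scatter), a step beyond the scatter, so the smaller plain amino group goes with the stronger inhibition of this pair. Among the compounds shown here, the earlier compounds varied only the chain on the aromatic nitrogen, so this is the first sign that a second site on the shared core also moves the number, and that removing all 6 heavy atoms of a ring there does not cost activity. Nothing among the data shown explains why the step runs in this direction.

Only the two extremes at this nitrogen are shown, hydrogen and cyclohexyl, so it remains open how a methyl group, an ethyl chain or a cyclopentyl ring would behave there, and whether the number changes smoothly with size. On these data alone, it is also open whether the plain amino group would give the same kind of step when combined with the propyl chain of compound 3 or with a longer butyl chain on the aromatic nitrogen.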